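A few compounds are considered here, and "the series" means these few. Any claim that something is new, unique, unknown or untested is made for them only; others in the source may bear on it.

Measured compounds:
compound 1, `Cc1ccc(-n2nc(C(=O)Nc3ccc(Oc4ncnc5ccsc45)cc3)c(C)cc2=O)cc1`, 25000 nM
compound 2, `Cc1cc(=O)n(-c2ccccc2OC(F)(F)F)nc1C(=O)Nc1ccc(Oc2ncnc3sccc23)cc1`, 14400 nM
compound 3, `Cc1cc(=O)n(-c2cccc(F)c2)nc1C(=O)Nc1ccc(Oc2ncnc3sccc23)cc1`, 18500 nM

All three were tested in a functional assay on HepG2 cells (Homo sapiens) for cytotoxicity, read by MTT assay, with a stated time of 72 h; on this read-out higher numbers stand for weaker inhibition and lower numbers for stronger inhibition. Compound 3 sits second highest of the three numbers; its nearest neighbour is compound 2 and its furthest is compound 1, and both gaps lie within the usual scatter of repeated measurements, so the three compounds cannot be told apart on these data.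

Compound 4, `Cc1ccc(-n2nc(C(=O)Nc3ccc(Oc4ncnc5sccc45)cc3)c(C)cc2=O)cc1`, has not yet been measured. It differs from compound 3 in one place: 4-methylphenyl in place of 3-fluorophenyl on an aromatic nitrogen.

Among the measured compounds shown here, only one measured step is closely related, the exchange of the group on the same aromatic nitrogen from compound 2 to compound 3, which gave a 1.3-fold higher number from compound 2 to compound 3 (0.11 log units; within the scatter). Compound 1 carries the same 4-methylphenyl group that enters in compound 4, though on a different shared core, and in this assay compound 1 gives 25000 nM. Both observations point to a number in the same flat region. No step beyond the scatter is therefore expected; the step from compound 3 to compound 4 is estimated at a 1.1-fold higher number from compound 3 to compound 4 (0.06 log units; within the scatter). Compound 4 is expected to give about 21000 nM, with a likely range from 8000 nM to 55000 nM.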

Compound 4, half-maximal inhibitory concentration: > 40000 nM
Compound 4: no number, only a limit (the forecaster's own chance of this, stated with the estimate: 15%); middle value at least 1.9-fold (0.27 log units) away from the limit.
By their numbers in this assay, from the lowest: compounds 2, 3 and 1 (each within the scatter of the next). At a limit, above all of these: compound 4.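

Compound 4 gives no number in this assay, only a limit: the limit of > 40000 nM in this assay, at which 1 of the 4 values shown sits.

Even so, the group on this aromatic nitrogen now matters in a way the earlier exchange did not show. That exchange, 3-fluorophenyl in place of 2-(trifluoromethoxy)phenyl, gave a 1.3-fold higher number from compound 2 to compound 3 (0.11 log units; within the scatter). With 4-methylphenyl in place of 3-fluorophenyl there is an at least 2.1-fold higher number from compound 3 to compound 4 (0.33 log units; beyond the scatter), and with 4-methylphenyl in place of 2-(trifluoromethoxy)phenyl there is an at least 2.7-fold higher number from compound 2 to compound 4 (0.44 log units; beyond the scatter); both are beyond the scatter and both are only floors for the true steps. On this core, then, the position is not flat for every aryl group, and the swap of 3-fluorophenyl for 4-methylphenyl, two groups of equal heavy-atom count, is enough to weaken the read-out. The exchange of the group on the oxygen gives an at least 1.6-fold higher number from compound 1 to compound 4 (0.20 log units; that floor lies within the scatter), so this comparison with the core of compound 1 shows no step beyond the scatter.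

As far as these compounds go, how far compound 4 really lies past its limit stays open, so the size of this change is unknown. Also open, from the compounds shown here alone, is how this position responds to other kinds of group, such as an amine or a carboxylic acid on the phenyl ring, or a plain unsubstituted phenyl.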